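The source may report more compounds than this note shows. Statements on the series, on what has been measured and on what is new or still open speak of the compounds shown alone.

Compound 1 `Cc1nc(COc2ccc(/C=C3\SC(=O)NC3=O)cc2)cs1` — 18.6%
Compound 2 `O=C1NC(=O)/C(=C/c2ccc(OCc3csc(-c4ccccc4)n3)cc2)S1` — 25.2%
Compound 3 `O=C1NC(=O)/C(=C/c2ccc(OCCSc3nnc(-c4ccccc4)[nH]3)cc2)S1` — 18.6%

All three compounds were tested in a functional assay on the whole organism (strain Wistar) with Rattus norvegicus as the target, with a stated time of 15 days, at a dose of 3 mg/kg by the oral route; a lower number here means a weaker effect, a higher number a stronger effect of the compound at the dose given. Compound 3 reads level with compound 1 at the digits shown, and the gap between compound 3 and compound 2 lies within the scatter of this kind of measurement, so none of the three can be set apart from the others on these numbers.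

Compound 4 `O=C1NC(=O)/C(=C/c2ccc(OCCSc3nnc(Cc4ccccc4)[nH]3)cc2)S1` is not yet measured. It differs from compound 3 in one place: benzyl in place of phenyl on an aromatic carbon.

For the measured compounds named here, only one measured step is available for comparison, a number 6.6 percentage points higher from compound 1 to compound 2 (within the scatter), which also changes the group on an aromatic carbon of a five-membered ring and stays within the scatter. That change is not the same as the present one, and nothing measured speaks directly to swapping phenyl for benzyl here. With no measured step beyond the scatter to lean on, no change beyond the scatter is expected: the step from compound 3 to compound 4 in this assay is estimated as a number 0.4 percentage points higher from compound 3 to compound 4 (within the scatter). Compound 4 is therefore expected to give about 19%, within a range from 8% to 30%.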

Compound 4, a percentage reported as activity, at one dose (the size of the read-out at that dose, not a potency): 22.5%
Compound 4: the middle estimate sits 3.5 percentage points below what was measured; measured number inside the range.
By their numbers in this assay, from the lowest: compounds 1, 3, 4 and 2 (each within the scatter of the next).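

In this assay, putting benzyl in place of phenyl on this aromatic carbon gives a number 3.9 percentage points higher from compound 3 to compound 4 (within the scatter) for a group of 7 heavy atoms in place of 6. So this position, on a five-membered aromatic ring with 3 nitrogen and between two ring nitrogen atoms, accepts the larger benzyl group with no difference that can be told apart from the scatter. Nothing measured here bears on the reason for this result.

The compounds shown leave open whether an amine or a carboxylic acid on this aromatic carbon would shift the read-out beyond the scatter. Going by these compounds, it also remains open whether phenylethyl, a longer chain ending in the same ring, would do so.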